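The compounds below may be only part of what the source reports. "The series", "measured", "known", "first", "only" and "open" are said of these compounds alone.

Measured so far:
compound 1 `C/N=C(\S)NCCCCCn1nc(-c2ccccc2)ccc1=O` — 35.3 mg/kg
compound 2 `C/N=C(/NC#N)NCCCCCn1nc(-c2ccccc2)ccc1=O` — 100 mg/kg
compound 3 `CC(C)(C)/N=C(\S)NCCCCn1nc(-c2ccccc2)ccc1=O` — only a limit in this assay

In a functional assay on the whole organism (stomach) with Rattus norvegicus as the target (a higher number here means that more compound is needed for the effect, a lower number that less compound is needed), compound 1 gives 35.3 mg/kg, the lowest of the two numbers that are known; the nearest is compound 2 with 100 mg/kg, so that a 2.8-fold higher number from compound 1 to compound 2 (0.45 log units; beyond the scatter). Compound 3 gives > 100 mg/kg, which is a limit of the assay and not a number (the limit of > 100 mg/kg in this assay, at which 1 of the 3 values shown sits). Against compound 1 this means an at least 2.8-fold higher number from compound 1 to compound 3 (0.45 log units; beyond the scatter), and against compound 2 it means a number no lower from compound 2 to compound 3 (the limit leaves the size open).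

Compound 4 `CC/N=C(\S)NCCCn1nc(-c2ccccc2)ccc1=O` has not been measured. Relative to compound 1 the change is a group of 6 heavy atoms (3 carbon, 2 nitrogen, 1 sulfur; no ring) in place of a group of 7 heavy atoms (4 carbon, 2 nitrogen, 1 sulfur; no ring), on a saturated chain carbon, three bonds along the chain from an aromatic nitrogen. Among the compounds with values here, the only measured step that bears on it is the one from compound 1 to compound 3, which also shortens the chain and enlarges the alkyl on the imine nitrogen and was at least modest upward. A step of similar direction is therefore expected: compound 4 is estimated to need more compound than compound 1, with a 2.3-fold higher number from compound 1 to compound 4 (0.36 log units; beyond the scatter). The estimate for compound 4 in this assay is 80 mg/kg, with a range from 35 mg/kg to 180 mg/kg.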

Compound 4, dose for half-maximal effect: > 100 mg/kg
Compound 4: a limit, no number (the forecaster's own chance of this, stated with the estimate: 40%); middle value at least 1.2-fold (0.09 log units) away from the limit.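

Compound 4 in this assay gives > 100 mg/kg, which is a limit of the assay and not a number: the limit of > 100 mg/kg in this assay, at which 2 of the 4 values shown sit.

The smaller group of 6 heavy atoms, on a saturated chain carbon, three bonds along the chain from an aromatic nitrogen, does not hold the level of compound 1: the result is an at least 2.8-fold higher number from compound 1 to compound 4 (0.45 log units; beyond the scatter) in this series. With an at least 2.8-fold higher number from compound 1 to compound 3 (0.45 log units; beyond the scatter) as the other case, upward steps from compound 1 now come with both a smaller and a larger group, and no listed compound goes against this.

The size of both steps stays unread past the limit, and chain length and the alkyl on the imine nitrogen change together in each. As far as these compounds go, whether a longer chain such as hexyl, or a methyl group kept on the shorter chain, would lower the number remains open.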